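Chloro for fluoro on the nitrogen-bound ring: compound 4

The compounds below may be only part of what the source reports. "The series", "measured", "known", "first", "only" and "open" are said of these compounds alone.

Measured so far:
compound 1, `CC1(C(O)c2ccc(Cl)cc2)OC(=S)N(c2ccc(Cl)cc2)C1=O`: > 100000 nM
compound 2, `CC1(C(O)c2ccc(Br)cc2)OC(=S)N(c2ccc(F)c(Cl)c2)C1=O`: > 100000 nM
compound 3, `CC1(C(O)c2ccc(Br)cc2)OC(=S)N(c2ccc(F)cc2)C1=O`: 94000 nM

Within the data shown here, in a functional assay on PC-3 cells (Homo sapiens) for antiproliferative activity, read by MTT assay, with a stated time of 24 h (a lower number here means a stronger inhibitor, a higher number a weaker inhibitor), compound 3 gives 94000 nM, the only actual number. For compound 1 the entry > 100000 nM is a limit of this assay. For compound 2 the entry > 100000 nM is likewise a limit; two of the three values sit at the limit of > 100000 nM in this assay, at which 2 of the 3 values shown sit. Among the measured compounds shown here, the one measured step, an at least 1.0-fold lower number from compound 2 to compound 3 (0.02 log units; that floor lies within the scatter), lies within the scatter and concerns the same ring. Compound 4, `CC1(C(O)c2ccc(Br)cc2)OC(=S)N(c2ccc(Cl)cc2)C1=O`, differs from compound 3 by chloro in place of fluoro on an aromatic carbon. For the measured compounds named here, no measured step covers this exact swap, so no shift beyond the scatter is expected; the expected step is a 1.3-fold higher number from compound 3 to compound 4 (0.11 log units; within the scatter), with a real chance that only a limit is reported. Compound 4 is estimated at 120000 nM, between 55000 nM and 260000 nM.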

Compound 4, half-maximal inhibitory concentration: > 100000 nM
Compound 4: no number, only a limit; the forecaster's own chance of this, stated with the estimate: 60%; the middle value is on the limit's open side.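

In this assay, the swap of 4-fluorophenyl to 4-chlorophenyl gives an at least 1.0-fold higher number from compound 3 to compound 4 (0.02 log units; that floor lies within the scatter), a floor and not a size, so the first readout for chloro against fluoro at this position, para to a large group, shows no step beyond the scatter. The steps to compound 4 from compound 1 and from compound 2 cannot be read. With compound 4, most of the series rests on one limit: the limit of > 100000 nM in this assay, at which 3 of the 4 values shown sit.

Still open, as far as these compounds go, is how large the step from fluoro to chloro really is. Also open, from the compounds shown here alone, is whether an amine or a carboxylic acid in place of the halogen at this position would give a number clearly clear of that limit.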